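Methyl in Place of Chloro Across Two Cores

The source may report more compounds than this note shows. Statements on the series, on what has been measured and on what is new or still open speak of the compounds shown alone.

Compound 1 `O=C(Nc1ncc(-c2ccccc2)o1)c1ccc(Cl)cc1` and compound 2 `Cc1ccc(C(=O)Nc2ncc(-c3ccccc3)o2)cc1` share one core. In a toxicity assay on THP-1 cells (Homo sapiens) for inhibition (on this read-out lower numbers stand for higher toxicity in this test and higher numbers for lower toxicity in this test), compound 1 gives 10000 nM, and compound 2 gives 26000 nM. The change between them, (methyl in place of chloro on an aromatic carbon), made a 2.6-fold higher number from compound 1 to compound 2 (0.41 log units; beyond the scatter). Compound 3 `Cn1c(-c2ccccc2)cnc1NC(=O)c1ccc(Cl)cc1` carries a different core, and how the two cores differ is not broken down here. In this assay compound 3 reaches only a limit, > 100000 nM. Compound 4 `Cc1ccc(C(=O)Nc2ncc(-c3ccccc3)n2C)cc1` is the unmeasured partner of compound 3, differing by methyl in place of chloro on an aromatic carbon; the place is worded exactly as in the first pair, so this is the same change. Compound 3 already sits at the limit of > 100000 nM in this assay, at which 1 of the 3 values shown sits, and the same change gave a 2.6-fold higher number from compound 1 to compound 2 (0.41 log units; beyond the scatter). On that basis compound 4 is expected to show a step that the limit leaves unreadable from compound 3 to compound 4, most likely ending as a limit again. In this assay compound 4 is estimated at 150000 nM, between 60000 nM and 500000 nM.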

Compound 4, half-maximal cytotoxic concentration: > 50000 nM
Compound 4 gave a limit, no number; the forecaster's own chance of this, stated with the estimate: 85%; the middle value does not contradict the limit.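

In this assay, among the compounds shown here, compound 3 and compound 4 both give only limits, and no step between them can be read. The compounds shown leave open whether methyl in place of chloro shifts the read-out on the core of compound 3 at all.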